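The source may hold more compounds than are shown below. What is called first, only, known or untested is meant among the compounds shown, and "the series" means these compounds.

Compound 1 `C[n+]1cccc(OP(=O)([O-])OC[C@H]2O[C@@H](n3cc(F)c(=O)[nH]c3=O)C[C@@H]2OC(=O)c2ccccc2)c1`: 1260 nM
Compound 2 `CCCCCCCCCC[n+]1cccc(OP(=O)([O-])OC[C@H]2O[C@@H](n3cc(F)c(=O)[nH]c3=O)C[C@@H]2OC(=O)c2ccccc2)c1`: 1200 nM
Compound 3 `O=C(O[C@H]1C[C@H](n2cc(F)c(=O)[nH]c2=O)O[C@@H]1COP(=O)([O-])Oc1ccc[n+](Cc2ccccc2)c1)c1ccccc1`: 530 nM

In a functional assay on HeLa cells (Homo sapiens) for cytotoxicity, read by MTT assay, with a stated time of 48 h (a higher number here means a weaker inhibitor, a lower number a stronger inhibitor), compound 3 has the lowest of the three numbers, which makes it the strongest inhibitor measured so far. Compound 4 `CCOC(=O)C[n+]1cccc(OP(=O)([O-])OC[C@H]2O[C@@H](n3cc(F)c(=O)[nH]c3=O)C[C@@H]2OC(=O)c2ccccc2)c1` has ethoxycarbonyl in place of phenyl on a saturated chain carbon bound to an aromatic nitrogen and the same difference reads as benzyl to (ethoxycarbonyl)methyl.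

Going by the values given here, three measured steps bear on this change. Phenyl in place of hydrogen gave a 2.4-fold lower number from compound 1 to compound 3 (0.38 log units; beyond the scatter) and phenyl in place of nonyl gave a 2.3-fold lower number from compound 2 to compound 3 (0.35 log units; beyond the scatter) and both steps are modest. Nonyl in place of hydrogen gave a 1.1-fold lower number from compound 1 to compound 2 (0.02 log units; within the scatter) and so made no clear difference. Among the compounds with values here, no measured compound carries ethoxycarbonyl, which leaves the evidence thin. With the phenyl gone, a modest rise in the number is expected, no larger than the size of a 2.3-fold lower number from compound 2 to compound 3 (0.35 log units; beyond the scatter) but running the other way. The estimated step is a 1.6-fold higher number from compound 3 to compound 4 (0.21 log units; within the scatter) in this assay as a best guess. Compound 4 is expected at 850 nM with an estimated range from 400 nM to 1800 nM.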

Compound 4, half-maximal inhibitory concentration: 6100 nM
Compound 4: the middle estimate sits 7.2-fold (0.86 log units) below what was measured, and the stated range ends below it.
By their numbers in this assay, from the lowest: compound 3; then compounds 2 and 1 (each within the scatter of the next); then compound 4.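

Until now, changing the group on this saturated chain carbon bound to an aromatic nitrogen had shifted the number modestly at most, but ethoxycarbonyl in place of phenyl gives a large step in this assay, a 12-fold higher number from compound 3 to compound 4 (1.06 log units; beyond the scatter) in size. Going by these compounds alone, the new group also stands apart from the other two, with ethoxycarbonyl in place of nonyl giving a 5.1-fold higher number from compound 2 to compound 4 (0.71 log units; beyond the scatter) and in place of hydrogen giving a 4.8-fold higher number from compound 1 to compound 4 (0.68 log units; beyond the scatter), so this position does respond to what is placed there, and ethoxycarbonyl, the only one of these groups with hydrogen-bond acceptors, gives the highest number. Nothing available explains this rise.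

From the compounds shown here alone, it remains open whether a carboxylic acid or an amide in place of ethoxycarbonyl would stay as high as compound 4. Going by these compounds, it is equally open whether a phenyl carrying a methoxy group would hold the low number of compound 3.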